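The compounds below may be only part of what the source reports. "The series", "measured", "known", "first", "only" and "open" are said of these compounds alone.

In a functional assay on A-431 cells (Homo sapiens) for inhibition, read by MTT assay, with a stated time of 72 h (on this read-out higher numbers stand for weaker inhibition and lower numbers for stronger inhibition), compound 1 `COc1ccc(-c2nnc(SCCCN3CCN(c4nc5ccccc5o4)CC3)o2)cc1` gives 52700 nM and compound 2 `Cc1ccc(-c2nnc(SCCCN3CCN(c4nc5ccccc5o4)CC3)o2)cc1` gives 100000 nM, so these two values lie within the usual scatter of each other. Compound 3 `Clc1ccc(-c2nnc(SCCCN3CCN(c4nc5ccccc5o4)CC3)o2)cc1` has chloro in place of methyl on an aromatic carbon, para to a large group: chloro in place of methyl on an aromatic carbon. Among the compounds with values here, the only measured step at this place, a 1.9-fold higher number from compound 1 to compound 2 (0.28 log units; within the scatter), stayed within the scatter, so no change beyond the scatter is expected in this assay. The estimated step is a 1.5-fold lower number from compound 2 to compound 3 (0.19 log units; within the scatter). Compound 3 is expected at 65000 nM, with an estimated range of 30000 nM to 140000 nM.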

Compound 3, half-maximal inhibitory concentration: 89600 nM
Beside the measured number, compound 3's estimate is 1.4-fold (0.14 log units) below it; the range from low to high includes it.
By their numbers in this assay, from the lowest: compounds 1, 3 and 2 (each within the scatter of the next).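

In this assay, chloro at this place, para to a large group, gives a third substituent to compare with methyl (a 1.1-fold lower number from compound 2 to compound 3 (0.05 log units; within the scatter)) and with methoxy (a 1.7-fold higher number from compound 1 to compound 3 (0.23 log units; within the scatter)). Both steps stay within the scatter, so this assay does not separate these three groups here. The data offer no explanation for this. As far as these compounds go, whether an amine or a carboxylic acid at this place would shift the number beyond the scatter remains open. So does the effect of changes elsewhere on the shared core.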